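Thiophen-3-yl for 1-benzofuran-2-yl on two cores

A few compounds are considered here, and "the series" means these few. Any claim that something is new, unique, unknown or untested is made for them only; others in the source may bear on it.

Measured compounds:
compound 1 `O=c1[nH]cnc2c1c(-c1ccsc1)cn2[C@@H]1O[C@H](CO)[C@@H](O)[C@H]1O` — > 20000 nM
compound 2 `O=c1[nH]cnc2c1c(-c1cc3ccccc3o1)cn2[C@@H]1O[C@H](CO)[C@@H](O)[C@H]1O` — > 20000 nM
compound 3 `Cc1nc(N)c2c(-c3cc4ccccc4o3)cn([C@@H]3O[C@H](CO)[C@@H](O)[C@H]3O)c2n1` — 6310 nM

In a functional assay on CEM-DNR-bulk cells (Homo sapiens), read by MTT assay, with a stated time of 72 h (on this read-out higher numbers stand for weaker inhibition and lower numbers for stronger inhibition), compound 2 gives > 20000 nM, which is a limit of the assay and not a number. In this assay compound 1 gives > 20000 nM, likewise a limit. For the measured compounds named here, compound 3 gives 6310 nM, the only number in the set. The change thiophen-3-yl in place of 1-benzofuran-2-yl on an aromatic carbon produced a step that the two limits leave unreadable from compound 2 to compound 1, unreadable because of the limit of > 20000 nM in this assay, at which 2 of the 3 values shown sit. The difference between the core of compound 2 and the core of compound 3 is not broken down here. Compound 4 `Cc1nc(N)c2c(-c3ccsc3)cn([C@@H]3O[C@H](CO)[C@@H](O)[C@H]3O)c2n1` carries the same change as thiophen-3-yl in place of 1-benzofuran-2-yl on an aromatic carbon. For compound 4 the step of a 1.6-fold higher number from compound 3 to compound 4 (0.20 log units; within the scatter) is expected, resting only on compound 3 at 6310 nM since the measured step gives no readable size. Compound 4 is estimated at 10000 nM, between 3000 nM and 30000 nM.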

Compound 4, half-maximal inhibitory concentration: > 20000 nM
Compound 4 was reported as a limit; the forecaster's own chance of this, stated with the estimate: 40%; middle value at least 2.0-fold (0.30 log units) away from the limit.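

In this assay, thiophen-3-yl in place of 1-benzofuran-2-yl on the core of compound 3 gives an at least 3.1-fold higher number from compound 3 to compound 4 (0.50 log units; beyond the scatter), a weakening beyond the scatter. Compound 4 sits at a limit and not a number, so only the lower bound of this step is known. The same change on the core of compound 2 cannot be read, so the step's carry-over between the two cores is neither confirmed nor refuted: the limit of > 20000 nM in this assay, at which 3 of the 4 values shown sit.

The compounds shown leave open whether an amine or a carboxylic acid at this aromatic carbon would keep a readable number on the core of compound 3. They also leave open how a group of this kind would read on the core of compound 2.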